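This account rests on a few compounds, and the source may have more. Where it says the series, first, only, none or still open, it means among the compounds named here.

Compound 1 `COc1ccc(S(=O)(=O)N2CCc3cccc(-c4cccnc4)c32)cc1`: 68.5 nM
Compound 2 `COc1ccc(S(=O)(=O)N2CCc3cccc(-c4ccc(O)cc4)c32)cc1`: 82.6 nM
Compound 3 `COc1ccc(S(=O)(=O)N2CCc3cccc(-c4cc(OC)c(OC)c(OC)c4)c32)cc1`: 1080 nM

Of the compounds shown here, three sharing one core have been measured in a functional assay on MKN-45 cells (Homo sapiens) for inhibition, with a stated time of 72 h; on this read-out higher numbers stand for weaker inhibition and lower numbers for stronger inhibition. Compound 2 stands second highest of the three numbers. Among the measured compounds shown here, compound 1 lies closest to it: the only single-place step measured so far, a 1.2-fold higher number from compound 1 to compound 2 (0.08 log units; within the scatter), swaps pyridin-3-yl for 4-hydroxyphenyl and stays within the scatter. For the measured compounds named here, compound 3 lies furthest, with a number clearly higher than that of compound 2, but these two differ in more than one place, so no single step is drawn between them.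

Compound 4 `COc1ccc(-c2cccc3c2N(S(=O)(=O)c2ccc(OC)cc2)CC3)cc1` has not yet been measured. It differs from compound 2 by methyl in place of hydrogen on an oxygen on an aromatic ring, that is, hydroxy to methoxy, 4-hydroxyphenyl to 4-methoxyphenyl. Going by the values given here, no measured step makes this exact exchange. Compound 3, which carries methoxy groups where compound 2 has hydroxy, gives a much higher number, a hint that methoxy on that ring may push the number up, though the change there is not a single one.

For compound 4 in this assay a modest rise is expected, a 1.8-fold higher number from compound 2 to compound 4 (0.26 log units; within the scatter), with a real chance of none beyond the scatter. Compound 4 is estimated at 150 nM, in a range from 60 nM to 400 nM.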

Compound 4, half-maximal inhibitory concentration: 211 nM
Beside the measured number, compound 4's estimate is 1.4-fold (0.15 log units) below it, within the range that was stated.
By their numbers in this assay, from the lowest: compounds 1 and 2 (each within the scatter of the next); then compound 4; then compound 3.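

In this assay, methyl in place of hydrogen on the oxygen, hydroxy to methoxy, gives a 2.6-fold higher number from compound 2 to compound 4 (0.41 log units; beyond the scatter) and so shows that even this one-carbon change can move the number beyond the scatter, which the earlier swap of pyridin-3-yl for 4-hydroxyphenyl did not do. The 4-methoxyphenyl group also differs from pyridin-3-yl on the same aromatic carbon, with a 3.1-fold higher number from compound 1 to compound 4 (0.49 log units; beyond the scatter) as the result, so the groups tried at this position do not all behave alike, although both steps are modest. Nothing measured here gives a reason for this rise.

Still open, going by these compounds, is how an ethoxy group or an amine, carried in place of the methoxy, would compare with hydroxy and methoxy. Also open, on these data alone, is whether the same exchange would give a similar step on a different core.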